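This account rests on a few compounds, and the source may have more. Where it says the series, first, only, none or still open, it means among the compounds named here.

Measured in a functional assay on RD cells (Homo sapiens) for inhibition, read by luminescence and ATP content, with a stated time of 72 h; a lower number here means that less compound is tolerated, a higher number that more compound is tolerated:
Compound 1 `CCc1nc(-c2cnc3ccc(-c4ccc(N)nc4)cc3c2)no1`: > 66700 nM, a limit
Compound 2 `CCCCc1ccc(-c2ccc3ncc(-c4noc(CC)n4)cc3c2)cc1`: > 7400 nM, a limit
Compound 3 `CCc1nc(-c2cnc3ccc(-c4ccc(C)cc4)cc3c2)no1`: > 7400 nM, a limit

Among the measured compounds shown here, each of these figures is a limit and not a number, so no compound here has an exact reading yet. Compound 3 stands at the limit of > 7400 nM in this assay, at which 2 of the 3 values shown sit.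

The next compound, compound 4 `CCc1nc(-c2cnc3ccc(-c4ccc(N)c(Cl)c4)cc3c2)no1`, keeps the shared core and alters one group: 4-amino-3-chlorophenyl in place of 4-methylphenyl on an aromatic carbon. A 4-amino-3-chlorophenyl takes the place of the 4-methylphenyl on an aromatic carbon of the core.

For the measured compounds named here, two measured steps bear on this change. One also exchanges a group on that aromatic carbon, with 4-methylphenyl in place of 6-aminopyridin-3-yl. The other only shortens the chain on the 4-methylphenyl, with hydrogen in place of propyl. The first, a step that the two limits leave unreadable from compound 1 to compound 3, gives no size to carry over, and the second, a step that the two limits leave unreadable from compound 2 to compound 3, gives none either, so no step beyond the usual scatter is expected, in either direction. A further limit is the most likely report for the new compound.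

The expected change is a step that the limit leaves unreadable from compound 3 to compound 4.

For compound 4 the estimated value is 12000 nM, with an expected range from 4000 nM to 60000 nM.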

Compound 4, half-maximal cytotoxic concentration: > 7400 nM
Compound 4: a limit, no number (the forecaster's own chance of this, stated with the estimate: 80%); the middle value is on the limit's open side.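

Compound 4 gives > 7400 nM, which is a limit and not a number. Its steps from compound 3 and from compound 1 cannot be read, since those readings are limits too. The compounds shown leave open what concentration of any of them is cytotoxic, and whether 4-amino-3-chlorophenyl, 4-methylphenyl and 6-aminopyridin-3-yl differ at all in this respect.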